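Hydrogen in place of the (1-bromoethenyl)carbonyl group

The compounds below may be only part of what the source reports. "The series", "measured", "known", "first", "only" and "open" are said of these compounds alone.

Going by the values given here, compound 1 `C=C(Br)C(=O)Nc1ccc(/C=C/C(=O)c2ccc(I)cc2)cc1` gives 3400 nM in a functional assay on L1210 cells (Mus musculus) for antiproliferative activity, with a stated time of 48 h (on this read-out lower numbers stand for stronger inhibition and higher numbers for weaker inhibition), the higher of the two numbers measured so far; compound 2 `C=C(Br)C(=O)Nc1ccc(/C=C/C(=O)c2cccs2)cc1` gives 250 nM. Among the compounds with values here, the only measured step, a 14-fold lower number from compound 1 to compound 2 (1.13 log units; beyond the scatter), alters the group on the carbonyl carbon and says nothing about the nitrogen end. Compound 3 `Nc1ccc(/C=C/C(=O)c2ccc(I)cc2)cc1` differs from compound 1 by hydrogen in place of (1-bromoethenyl)carbonyl on a nitrogen on an aromatic ring. Within the data shown here, with no measured step bearing on this change, the number is expected to rise, a 2.6-fold higher number from compound 1 to compound 3 (0.42 log units; beyond the scatter), and the expectation is loose. Compound 3 is estimated at 9000 nM, within a range from 2000 nM to 40000 nM.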

Compound 3, half-maximal inhibitory concentration: 50000 nM
Compound 3: the middle estimate sits 5.6-fold (0.74 log units) below what was measured; measured number outside the range, above it.
By their numbers in this assay, from the lowest: compound 2; then compound 1; then compound 3.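

Compound 3 carries hydrogen in place of the (1-bromoethenyl)carbonyl group on the nitrogen. This change is a large loss in this assay (a 15-fold higher number from compound 1 to compound 3 (1.17 log units; beyond the scatter)). This shows that the nitrogen end of compound 1 strongly affects the read-out, which the earlier change on the carbonyl carbon could not show. The data offer no explanation for this loss.

As far as these compounds go, it remains open whether the bromine or the rest of the removed group matters, which a simple acetyl group on the nitrogen would help test. From the compounds shown here alone, whether the same loss occurs with thiophen-2-yl in place of 4-iodophenyl also remains open.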